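Adding a Second Fluoro to a Glutamate Receptor Agonist

The source may report more compounds than this note shows. Statements on the series, on what has been measured and on what is new or still open speak of the compounds shown alone.

In a functional assay on CHO cells for agonist activity at metabotropic glutamate receptor 2 (Homo sapiens), read by scintillation counting and GTPgammaS binding, with a stated time of 30 min (on this read-out lower numbers stand for an effect already at smaller amounts and higher numbers for an effect only at larger amounts of compound), compound 1 `COc1c(F)cccc1C1CCN(c2ccn3c(CC4CC4)nnc3c2Cl)CC1` gives 37 nM, compound 2 `COc1c(F)ccc(F)c1C1CCN(c2ccn3c(CC4CC4)nnc3c2Cl)CC1` gives 7.5 nM, and compound 3 `COc1c(F)cccc1C1CCN(c2ccn3c(CC4CC4)nnc3c2C(F)(F)F)CC1` gives 11 nM. Among these three numbers compound 3 is clearly separated only from compound 1: the step of a 3.4-fold lower number from compound 1 to compound 3 (0.53 log units; beyond the scatter) lies beyond the scatter, while its difference from compound 2 is within the scatter. Compound 4 `COc1c(F)ccc(F)c1C1CCN(c2ccn3c(CC4CC4)nnc3c2C(F)(F)F)CC1` differs from compound 3 by fluoro in place of hydrogen on an aromatic carbon. The same change, made on the core of compound 1, gave a 4.9-fold lower number from compound 1 to compound 2 (0.69 log units; beyond the scatter), a modest step beyond the scatter. The step expected in this assay is therefore of similar size, a 3.1-fold lower number from compound 3 to compound 4 (0.50 log units; beyond the scatter). Compound 4 is accordingly estimated at 3.5 nM, with a range from 1.2 nM to 10 nM.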

Compound 4, half-maximal effective concentration: 4.1 nM
Estimate against measurement, compound 4: 1.2-fold (0.07 log units) below; the measured number falls inside the stated range.
By their numbers in this assay, from the lowest: compounds 4, 2 and 3 (each within the scatter of the next, the first and the last beyond it); then compound 1.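

The change from 3-fluoro-2-methoxyphenyl to 3,6-difluoro-2-methoxyphenyl now appears on a second core, with a 2.7-fold lower number from compound 3 to compound 4 (0.43 log units; beyond the scatter). The size of this step agrees with the earlier one, so the fluoro gain at this position is not confined to the chloro core: the same change on two cores in this assay, a 4.9-fold lower number (0.69 log units; beyond the scatter) from compound 1 to compound 2 and a 2.7-fold lower number (0.43 log units; beyond the scatter) from compound 3 to compound 4, 1.8-fold (0.26 log units) apart, within the scatter of two such steps. Trifluoromethyl in place of chloro, on the compounds carrying both fluoro groups, gives only a 1.8-fold lower number from compound 2 to compound 4 (0.26 log units; within the scatter), yet this step cannot be told apart from the earlier chloro swap: the same change on two cores in this assay, a 3.4-fold lower number (0.53 log units; beyond the scatter) from compound 1 to compound 3 and a 1.8-fold lower number (0.26 log units; within the scatter) from compound 2 to compound 4, 1.8-fold (0.26 log units) apart, within the scatter of two such steps.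

The compounds shown leave open whether a methyl, a chloro or an amine at this position would lower the number as fluoro does.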